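The source may hold more compounds than are shown below. What is called first, only, known or untested is meant among the compounds shown, and "the series" means these compounds.

Working notes on the series, following the step from compound 2 to compound 3.

Compound 1 `CC(=O)N[C@H]1[C@H]([C@@H](O)[C@H](O)CNC(=O)c2ccc(Cl)cc2)O[C@@](OCc2ccc(Cl)cc2)(C(=O)O)C[C@@H]1O` and compound 2 `CC(=O)N[C@H]1[C@H]([C@@H](O)[C@H](O)CNC(=O)c2ccc(Cl)cc2)O[C@@](OCc2cccc(F)c2F)(C(=O)O)C[C@@H]1O` share the whole core and differ only in the aryl group on the saturated chain carbon bound to an oxygen on a saturated carbon. In a physicochemical assay for lipophilicity, using the shake flask method, measured as octanol-water partition, at pH 7.4 (a higher number here means a more lipophilic compound, a lower number a more polar compound), compound 1 gives 0.36 and compound 2 gives -0.27, so compound 2 stands lowest of the two numbers, with compound 1 the nearest and higher. Among the measured compounds shown here, the one measured step, a number 0.63 log units lower from compound 1 to compound 2 (beyond the scatter), is beyond the scatter and of modest size.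

Compound 3 `O=C(CC1CC1)N[C@H]1[C@H]([C@@H](O)[C@H](O)CNC(=O)c2ccc(Cl)cc2)O[C@@](OCc2cccc(F)c2F)(C(=O)O)C[C@@H]1O` is to be measured next. It keeps the 2,3-difluorophenyl group of compound 2 and differs from it by cyclopropyl in place of hydrogen on a saturated chain carbon bound to a carbonyl carbon. For the measured compounds named here, the measured step from compound 1 to compound 2 concerns a change at another place and gives no direct guide here; no measured pair in this set shows an acetyl to (cyclopropylmethyl)carbonyl exchange. The expectation for compound 3 therefore rests on the change alone: three carbons enter and no donor or acceptor is added, so a step upward in this assay is expected, estimated as a number 0.92 log units higher from compound 2 to compound 3 (beyond the scatter). For compound 3 the expected value is 0.65, with a range from 0.15 to 1.15.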

Compound 3, distribution coefficient: 0.31
For compound 3 the middle estimate is 0.34 log units above the measured one; low and high end bracket the measured number.
By their numbers in this assay, from the lowest: compound 2; then compounds 3 and 1 (each within the scatter of the next).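

In this assay, the place on the saturated chain carbon bound to a carbonyl carbon gives its first reading in this series: with the 2,3-difluorophenyl group held in place, cyclopropyl in place of hydrogen, which turns acetyl into (cyclopropylmethyl)carbonyl, gives a number 0.58 log units higher from compound 2 to compound 3 (beyond the scatter). Among the compounds shown here, the only earlier step concerned the aryl group at another place, so this result adds a second site in the shared core where a single change moves the number beyond the scatter, this time upward and again by a modest amount. No measured information on the origin of this step is at hand.

The compounds shown leave open whether the step belongs to the three-membered ring or simply to the carbons that enter, a question that a straight propyl or isobutyl chain at the same place would address, while a primary amine or a carboxylic acid on that chain would test the opposite direction. They also leave open whether the same exchange gives a similar step with the 4-chlorophenyl group of compound 1 in place of the 2,3-difluorophenyl group.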